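This account rests on a few compounds, and the source may have more. Where it says the series, first, only, none or still open, it means among the compounds named here.

In a functional assay on MDA-MB-231 cells (Homo sapiens) for cytotoxicity, read by MTT assay, with a stated time of 24 h (on this read-out lower numbers stand for stronger inhibition and higher numbers for weaker inhibition), compound 1 (`CCCCCCCCCCCC(=O)Nc1nnc(S[C@@H]2O[C@H](COC(C)=O)[C@H](OC(C)=O)[C@H](OC(C)=O)[C@H]2OC(C)=O)s1`) gives 26700 nM, while compound 2 (`CCCCCCCCCCCCCCCCCC(=O)Nc1nnc(S[C@@H]2O[C@H](CO)[C@H](O)[C@H](O)[C@H]2O)s1`) gives 67100 nM. Compound 2 thus holds the higher of the two numbers, and the gap between them lies beyond the usual scatter. Compound 3 (`CCCCCCCCCC(=O)Nc1nnc(S[C@@H]2O[C@H](CO)[C@H](O)[C@H](O)[C@H]2O)s1`) departs from compound 2 by a single change along the chain: hydrogen in place of octyl on a saturated chain carbon, nine bonds along the chain from a carbonyl carbon. Among the measured compounds shown here, no two measured compounds differ in this one place, so the expectation is loose: a modest step toward a lower number in this assay, a 1.5-fold lower number from compound 2 to compound 3 (0.17 log units; within the scatter), which is only an estimate and may not clear the scatter. For compound 3 the estimated value is 45000 nM, with an expected range of 20000 nM to 100000 nM.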

Compound 3, half-maximal inhibitory concentration: 53100 nM
The estimate for compound 3 lay 1.2-fold (0.07 log units) below the measured number; the range from low to high includes it.
By their numbers in this assay, from the lowest: compounds 1, 3 and 2 (each within the scatter of the next, the first and the last beyond it).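

In this assay, among the compounds shown here, hydrogen in place of octyl on a saturated chain carbon, nine bonds along the chain from a carbonyl carbon, gives a 1.3-fold lower number from compound 2 to compound 3 (0.10 log units; within the scatter) and is the first single-place comparison. At this position, losing the octyl portion of the chain therefore leaves compound 3 indistinguishable from compound 2 within the scatter. Nothing available explains this result. From the compounds shown here alone, whether a longer chain, or an amine or a carboxylic acid in place of octyl, would move the number beyond the scatter remains open.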